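The source may hold more compounds than are shown below. What is called first, only, known or untested is meant among the compounds shown, and "the series" means these compounds.

Measured compounds in an assay on isolated protein for displacement of a labelled ligand from 5-hydroxytryptamine receptor 6 (Homo sapiens); a higher number here means a weaker inhibitor, a lower number a stronger inhibitor:
- compound 1, `O=C1CN=C(NC[C@@H]2CCCc3cc(S(=O)(=O)c4cccc(F)c4)ccc32)N1`, gives 0.1 nM
- compound 2, `O=C(NC[C@@H]1CCCc2cc(S(=O)(=O)c3cccc(F)c3)ccc21)c1ccc[nH]1`, gives 5.01 nM
- compound 3, `O=C1CN(C[C@@H]2CCCc3cc(S(=O)(=O)c4cccc(F)c4)ccc32)CCN1`, gives 6.31 nM

Compound 3 gives the highest number of the three, but its gap to compound 2 is within the scatter a 1.3-fold higher number from compound 2 to compound 3 (0.10 log units; within the scatter), while compound 1 sits far below both a 63-fold higher number from compound 1 to compound 3 (1.80 log units; beyond the scatter). Compound 4, `CNCC(=O)NC[C@@H]1CCCc2cc(S(=O)(=O)c3cccc(F)c3)ccc21`, keeps the shared core and changes only the side group: (((methylamino)methyl)carbonyl)amino in place of 3-oxopiperazin-1-yl on a saturated chain carbon bound to a saturated ring carbon. Going by the values given here, the step that bears most on this is the one between compound 2 and compound 3, where an open-chain carbonyl-bearing amino group and the ring-closed 3-oxopiperazin-1-yl gave numbers within the scatter of each other. Compound 4 again carries an open-chain carbonyl-bearing amino group, so no step beyond the scatter is expected in this assay , with the estimated step being a 1.1-fold lower number from compound 3 to compound 4 (0.02 log units; within the scatter). Compound 4 is therefore expected to give about 6 nM, within a range from 2 nM to 25 nM.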

Compound 4, inhibition constant: 0.159 nM
Compound 4: the middle estimate sits 38-fold (1.58 log units) above what was measured, and the stated range ends above it.
By their numbers in this assay, from the lowest: compounds 1 and 4 (each within the scatter of the next); then compounds 2 and 3 (each within the scatter of the next).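

Having a carbonyl-bearing amino group in an open chain on this saturated chain carbon does not by itself fix the result in this assay: replacing 3-oxopiperazin-1-yl with (((methylamino)methyl)carbonyl)amino gives a 40-fold lower number from compound 3 to compound 4 (1.60 log units; beyond the scatter). What sits on the carbonyl carbon matters greatly, since (methylamino)methyl in place of 1H-pyrrol-2-yl gives a 32-fold lower number from compound 2 to compound 4 (1.50 log units; beyond the scatter), while the open chain of compound 4 stays within the scatter of the five-membered ring group of compound 1, with a 1.6-fold higher number from compound 1 to compound 4 (0.20 log units; within the scatter). No measurement at hand explains these steps.

As far as these compounds go, whether the methylamino end itself is needed remains open. How a hydroxyl or dimethylamino group in its place, or a longer chain leading to the amine, would read in this assay cannot be told from these compounds.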